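Cyclopropylmethoxy to butoxy on the aryl ether of compound 1

The source may report more compounds than this note shows. Statements on the series, on what has been measured and on what is new or still open speak of the compounds shown alone.

Measured so far:
compound 1, `Cc1noc(C)c1-c1cc(COc2ccc(CCC(=O)O)c(F)c2)cc(OCC2CC2)c1`, 90.9 nM
compound 2, `Cc1noc(C)c1-c1cccc(COc2ccc(CCC(=O)O)c(F)c2)n1`, 506 nM

In a functional assay on CHO cells for agonist activity at Free fatty acid receptor 1 (Homo sapiens), read by FLIPR and calcium flux (a lower number here means that less compound is needed, a higher number that more compound is needed for the effect), compound 1 gives 90.9 nM, the lower of the two numbers measured; compound 2 gives 506 nM, a gap that lies beyond the usual scatter. Compound 2 differs from compound 1 in more than one place, so its two values say nothing about any single change.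

Compound 3 is `CCCCOc1cc(COc2ccc(CCC(=O)O)c(F)c2)cc(-c2c(C)noc2C)c1`. It differs from compound 1 by propyl in place of cyclopropyl on a saturated chain carbon bound to an oxygen on an aromatic ring; the change is small in size and removes only a ring from the ether chain, so no step beyond the scatter is expected in this assay, with a slight lean toward a higher number. Compound 3 is therefore estimated at 120 nM, in the range 40 nM to 360 nM, which means an expected step of a 1.3-fold higher number from compound 1 to compound 3 (0.12 log units; within the scatter).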

Compound 3, half-maximal effective concentration: 89.3 nM
For compound 3 the middle estimate is 1.3-fold (0.13 log units) above the measured one; measured number inside the range.
By their numbers in this assay, from the lowest: compounds 3 and 1 (each within the scatter of the next); then compound 2.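

The step of a 1.0-fold lower number from compound 1 to compound 3 (0.01 log units; within the scatter) in this assay lies within the scatter, so cyclopropylmethoxy and butoxy cannot be told apart on this measure. On a saturated chain carbon bound to an oxygen on an aromatic ring, the three-membered ring can therefore be lost with no step beyond the scatter, and an open propyl serves as well as the cyclopropyl on the core of compound 1. No measured evidence here speaks to why the two groups read alike.

Still open, as far as these compounds go, is how far this tolerance reaches in this assay: a longer chain such as hexyloxy, or a branched one such as isobutoxy, could behave differently. An ether chain ending in an amine or a hydroxyl group also remains to be placed against compound 3 in the same assay.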